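Bromo in place of 1-methylethenyl on a thiophene-bearing amine

A few compounds are considered here, and "the series" means these few. Any claim that something is new, unique, unknown or untested is made for them only; others in the source may bear on it.

Measured compounds:
Compound 1 `Cc1ccc(CN[C@@H]2C[C@H]3C[C@@H]([C@H]2C)C3(C)C)s1`: 780 nM
Compound 2 `C=C(C)c1csc(CN[C@@H]2C[C@H]3C[C@@H]([C@H]2C)C3(C)C)c1`: 25000 nM

Of the compounds shown here, two have been measured in an ADME assay on MDCK cells (Canis lupus familiaris) for cytotoxicity, read by microscopy, with a stated time of 48 h; a lower number here means that less compound is tolerated, a higher number that more compound is tolerated. Compound 1 `Cc1ccc(CN[C@@H]2C[C@H]3C[C@@H]([C@H]2C)C3(C)C)s1` gives 780 nM. Compound 2 `C=C(C)c1csc(CN[C@@H]2C[C@H]3C[C@@H]([C@H]2C)C3(C)C)c1` gives 25000 nM, the highest of the two numbers; the gap between compound 1 and compound 2 lies well beyond the scatter, so compound 2 is tolerated at clearly higher concentrations. Compound 3 `C[C@H]1[C@H](NCc2cc(Br)cs2)C[C@H]2C[C@@H]1C2(C)C` has not yet been measured. Relative to compound 2, the change is bromo in place of 1-methylethenyl on an aromatic carbon. Among the measured compounds shown here, no measured pair isolates this exchange, so the expectation rests only on compound 1 and compound 2. A step from compound 2 to compound 3 of a 5.0-fold lower number from compound 2 to compound 3 (0.70 log units; beyond the scatter) is expected, a fall that goes beyond the scatter, because compound 1 with its methyl gives 780 nM. For compound 3 a value of 5000 nM is estimated, within 1000 nM to 25000 nM.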

Compound 3, minimum cytotoxic concentration: 6250 nM
The estimate for compound 3 lay 1.3-fold (0.10 log units) below the measured number, within the range that was stated.
By their numbers in this assay, from the lowest: compound 1; then compound 3; then compound 2.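

In this assay the exchange of 1-methylethenyl for bromo gives a 4.0-fold lower number from compound 2 to compound 3 (0.60 log units; beyond the scatter) and so shows that the group on this aromatic carbon, two ring bonds from the ring sulfur, can shift the number even when a single bromine replaces three carbons. Placing 4-bromothiophen-2-yl where compound 1 has 5-methylthiophen-2-yl gives an 8.0-fold higher number from compound 1 to compound 3 (0.90 log units; beyond the scatter) and puts compound 3 in the middle of the three compounds, with both steps beyond the usual scatter. Nothing shown here accounts for either step.

From the compounds shown here alone, it remains open how an amine, a carboxylic acid or a longer chain on this aromatic carbon would compare with bromo and 1-methylethenyl. The step from compound 1 also leaves unsettled how much depends on the group itself and how much on where it sits on the ring.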